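This account rests on a few compounds, and the source may have more. Where it says the series, first, only, none or still open, it means among the compounds named here.

Compound 1 `Cc1cc(C#N)cc(C)c1Oc1nc(NC2CCC(NC(=O)c3ccc(F)cc3)CC2)nc2ccsc12` gives 3180 nM in an ADME assay on MT4 cells (Homo sapiens) for cytotoxicity, read by MTT assay, with a stated time of 5 days; on this read-out higher numbers stand for lower toxicity in this test and lower numbers for higher toxicity in this test.
Compound 2 `Cc1cc(C#N)cc(C)c1Oc1nc(NC2CCC(NC(=O)c3ccc(C#N)cc3)CC2)nc2ccsc12` gives 2620 nM in this assay.

Compound 2 and compound 1 share the same core and differ only at the benzamide end, and their two numbers in this assay lie within the scatter of each other: the step is a 1.2-fold lower number from compound 1 to compound 2 (0.08 log units; within the scatter). On the numbers shown, compound 2 therefore stands level with compound 1, with nothing to separate the two.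

Compound 3 `Cc1cc(C#N)cc(C)c1Oc1nc(NC2CCC(NC(=O)c3cccc(C(F)(F)F)c3)CC2)nc2ccsc12` has not yet been measured. It differs from compound 2 in one place: 3-(trifluoromethyl)phenyl in place of 4-cyanophenyl on a carbonyl carbon. Among the compounds with values here, the only measured step that touches this part of the molecule is the one from compound 1 to compound 2, which swapped one substituent on the same phenyl ring and stayed within the scatter. Within the data shown here, no measured pair speaks to a trifluoromethyl group or to a substituent set at the 3-position, so the expectation rests on that single step alone, and it points to no change beyond the scatter.

Compound 3 is expected to give about 3000 nM in this assay, within a range of 1200 nM to 7500 nM. This estimate means a step of a 1.1-fold higher number from compound 2 to compound 3 (0.06 log units; within the scatter), which is expected to stay within the scatter.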

Compound 3, half-maximal cytotoxic concentration: 3240 nM
Compound 3: middle estimate off by 1.1-fold (0.03 log units), on the low side; the measured number falls inside the stated range.
By their numbers in this assay, from the lowest: compounds 2, 1 and 3 (each within the scatter of the next).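

On a carbonyl carbon, 3-(trifluoromethyl)phenyl in place of 4-cyanophenyl gives a 1.2-fold higher number from compound 2 to compound 3 (0.09 log units; within the scatter) in this assay, and the same group in place of 4-fluorophenyl gives a 1.0-fold higher number from compound 1 to compound 3 (0.01 log units; within the scatter). The earlier pair had shown only that one substituent could replace another on a 4-substituted phenyl, whereas this result extends the comparison to a group of 10 heavy atoms in place of one of 8, with a different substituent and a different numbered place on the ring, and compound 1, compound 2 and compound 3 still cannot be separated on this read-out. No supporting measurement bears on why these numbers stay together.

The change from compound 2 to compound 3 alters the substituent and its numbered place together, so the compounds shown cannot separate the two. Going by these compounds, it also remains open whether an amine or a carboxylic acid on this phenyl ring, or a longer chain in place of the ring on the carbonyl carbon, would carry the number beyond the scatter.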